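The source may report more compounds than this note shows. Statements on the series, on what has been measured and on what is new or still open speak of the compounds shown alone.

In an ADME assay on HT-29 cells (Homo sapiens) for cytotoxicity, read by sulforhodamine B assay, with a stated time of 24 h (a higher number here means that more compound is tolerated, a lower number that less compound is tolerated), compound 2 `O=C(/C=C/c1cc2ccccc2[nH]c1=O)c1ccc(O)cc1` gives 41400 nM. Within the data shown here, that is the only plain number in this assay; the other value is a limit. Compound 1 `COc1ccc(C(=O)/C=C/c2cc3ccccc3[nH]c2=O)cc1` reaches only the limit of > 100000 nM in this assay. The step between them is an at least 2.4-fold lower number from compound 1 to compound 2 (0.38 log units; beyond the scatter), which means that compound 2 is tolerated less well than compound 1, by a margin that runs beyond the scatter of repeated measurements, though its true size is hidden by the limit of > 100000 nM in this assay, at which 1 of the 2 values shown sits.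

Compound 3 `O=C(/C=C/c1cc2ccccc2[nH]c1=O)c1ccc(Cl)cc1` has not yet been measured. It differs from compound 2 in one place: chloro in place of hydroxy on an aromatic carbon. Among the measured compounds shown here, only one measured step touches this position, the removal of the methyl from the oxygen, and that step lowered the number. Compound 3 keeps neither the methyl nor the hydroxy, so that step gives only a loose guide; a step of at most modest size is expected, more likely back toward the limit than away from it. On this basis the expected step is a 1.6-fold higher number from compound 2 to compound 3 (0.20 log units; within the scatter), and the estimate for compound 3 in this assay is 65000 nM, within a range from 20000 nM to 150000 nM.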

Compound 3, concentration lethal to 50% of the cells: > 100000 nM
Compound 3 gave a limit, no number; the forecaster's own chance of this, stated with the estimate: 30%; middle value at least 1.5-fold (0.18 log units) from the limit.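

In this assay, putting chloro in place of hydroxy on this aromatic carbon, para to a large group, gives an at least 2.4-fold higher number from compound 2 to compound 3 (0.38 log units; beyond the scatter), so a second replacement of the hydroxy now separates from compound 2, and the earlier methyl step no longer stands alone. The values of compound 1 and compound 3 are both limits and not numbers, which leaves compound 2, the 4-hydroxyphenyl compound, as the only one of the three with a plain number, whereas the methoxy and chloro compounds both reach the limit. The step from compound 1 to compound 3 cannot be read: the limit of > 100000 nM in this assay, at which 2 of the 3 values shown sit.

How far compound 1 and compound 3 truly lie from compound 2 stays hidden, and three compounds cannot show whether the lower number belongs to the hydroxy alone. The compounds shown also do not tell what an amine or a carboxylic acid would do at this same place on the ring.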